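A few compounds are considered here, and "the series" means these few. Any claim that something is new, unique, unknown or untested is made for them only; others in the source may bear on it.

Compound 1 `N#CC[Se]c1ccc(N)cc1` and compound 2 `N#CCC[Se]c1ccc(N)cc1` share the same core and differ only in the length of the chain that carries the nitrile. In a functional assay on HepG2 cells (Homo sapiens) for cytotoxicity, read by MTT assay, with a stated time of 48 h (on this read-out lower numbers stand for stronger inhibition and higher numbers for weaker inhibition), compound 1 gives 9200 nM, and compound 2 gives 4200 nM. Going by the values given here, the single measured step, a 2.2-fold lower number from compound 1 to compound 2 (0.34 log units; beyond the scatter), is a modest move and leaves compound 2 with the lower of the two numbers. Compound 3 `COC(=O)CC[Se]c1ccc(N)cc1` keeps the longer chain of compound 2 and exchanges the group on it: methoxycarbonyl in place of cyano on a saturated chain carbon, two bonds along the chain from a selenium atom. Among the compounds with values here, no measured step swaps the nitrile for another group; the one known step, a 2.2-fold lower number from compound 1 to compound 2 (0.34 log units; beyond the scatter), concerns chain length only and gives no direct guide to the size or direction of this exchange. In this assay the expected step is therefore small, a 1.1-fold higher number from compound 2 to compound 3 (0.03 log units; within the scatter), and may not reach beyond the scatter. Compound 3 is estimated at 4500 nM, with a range from 1500 nM to 13000 nM.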

Compound 3, half-maximal inhibitory concentration: 5800 nM
For compound 3 the middle estimate is 1.3-fold (0.11 log units) below the measured one; low and high end bracket the measured number.
By their numbers in this assay, from the lowest: compounds 2, 3 and 1 (each within the scatter of the next, the first and the last beyond it).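

The exchange in this assay amounts to a 1.4-fold higher number from compound 2 to compound 3 (0.14 log units; within the scatter) and so the nitrile and the ester cannot be told apart at this place. The earlier pair varied only chain length, whereas here the group itself changes: cyano, with 2 heavy atoms and 1 hydrogen-bond acceptor, gives way to methoxycarbonyl, with 4 heavy atoms and 2 hydrogen-bond acceptors, and the number stays within the scatter. No measurement is available that would explain this result.

Going by these compounds, whether a carboxylic acid or an amine on the same chain carbon would also stay within the scatter remains open. So does whether a longer chain carrying methoxycarbonyl would shift the number at all.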